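A few compounds are considered here, and "the series" means these few. Any claim that something is new, unique, unknown or untested is made for them only; others in the source may bear on it.

In an ADME assay on L02 cells (Homo sapiens) for cytotoxicity, read by MTT assay, with a stated time of 24 h (on this read-out higher numbers stand for lower toxicity in this test and lower numbers for higher toxicity in this test), compound 3, `O=c1[nH]cc(S(=O)(=O)Nc2cccc(-c3cn(-c4cccc(Cl)c4)nn3)c2)c(=O)[nH]1`, gives 8330 nM. Among the compounds with a number in this assay, compound 3 stands at the lowest value, and the nearest other number belongs to compound 1, `Cc1ccc(-n2cc(-c3cccc(NS(=O)(=O)c4c[nH]c(=O)[nH]c4=O)c3)nn2)cc1`, which gives 23100 nM. A third compound, compound 2, `O=c1[nH]cc(S(=O)(=O)Nc2cccc(-c3cn(-c4ccc(F)cc4)nn3)c2)c(=O)[nH]1`, is recorded in this assay as "not toxic" (no number reported), so for it no number exists and it cannot be placed on the same scale.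

The compound to consider next is compound 4, `O=c1[nH]cc(S(=O)(=O)Nc2cccc(-c3cn(-c4ccc(Cl)cc4)nn3)c2)c(=O)[nH]1`. It differs from compound 3 by 4-chlorophenyl in place of 3-chlorophenyl on an aromatic nitrogen. For the measured compounds named here, the one step measured so far, a 2.8-fold lower number from compound 1 to compound 3 (0.44 log units; beyond the scatter), replaces a 4-methylphenyl with a 3-chlorophenyl, so it changes both the group and its place at once and bears on the present change only loosely. The two compounds carrying a group at the same place as in compound 4, compound 1 and compound 2, sit at the higher number or beyond any number. On that basis a step back toward higher numbers, a 1.6-fold higher number from compound 3 to compound 4 (0.19 log units; within the scatter), is expected for compound 4, with wide uncertainty.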

Compound 4, half-maximal cytotoxic concentration: 9860 nM
Estimate against measurement, compound 4: 1.3-fold (0.12 log units) above, and the stated range covers the measured number.
By their numbers in this assay, from the lowest: compounds 3 and 4 (each within the scatter of the next); then compound 1.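

Swapping 3-chlorophenyl for 4-chlorophenyl on the aromatic nitrogen in this assay gives a step within the scatter (a 1.2-fold higher number from compound 3 to compound 4 (0.07 log units; within the scatter)), so among these two compounds the place of the chlorine makes no readable difference. With the place held fixed, the group can now be read on its own, and chloro in place of methyl gives a modest step beyond the scatter (a 2.3-fold lower number from compound 1 to compound 4 (0.37 log units; beyond the scatter)), which suggests that the earlier step to compound 3 goes with the chloro and not with where it sits. Nothing measured here explains why chloro and methyl differ.

Going by these compounds, whether a group of another kind on this ring, such as an amine or a carboxylic acid, would shift the number further remains open. Compound 2 has no number, so its steps to the other compounds cannot be read.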